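Working notes on compound 4 against three measured analogues

The source may hold more compounds than are shown below. What is called first, only, known or untested is meant among the compounds shown, and "the series" means these compounds.

For the measured compounds named here, compound 3 `CC(=O)Nc1ccc([C@@H](C)NCC2CCN(CCCc3c[nH]c4ccc(-n5cnnc5)cc34)CC2)cc1` gives 8.9 nM in an assay on CHO cells for displacement of a labelled ligand from 5-hydroxytryptamine receptor 1B (Homo sapiens) (on this read-out lower numbers stand for stronger inhibition and higher numbers for weaker inhibition), the lowest of the three numbers so far. Compound 1 `C[C@@H](NCC1CCN(CCCc2c[nH]c3ccc(-n4cnnc4)cc23)CC1)c1ccccc1` gives 14 nM; the gap a 1.6-fold lower number from compound 1 to compound 3 (0.20 log units; within the scatter) is within the scatter, so the two cannot be ordered. Compound 2 `CN(Cc1cccs1)C1CCN(CCCc2c[nH]c3ccc(-n4cnnc4)cc23)CC1` gives 140 nM, and the step of a 10-fold higher number from compound 1 to compound 2 (1.00 log units; beyond the scatter) is beyond the scatter.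

Compound 4 `c1ccc2c(c1)CCC2NCC1CCN(CCCc2c[nH]c3ccc(-n4cnnc4)cc23)CC1` carries the change (2,3-dihydro-1H-inden-1-yl in place of 1-(4-acetamidophenyl)ethyl on an amine nitrogen). Going by the values given here, two measured steps bear on it. The acetamido part of the leaving group was added in the step of a 1.6-fold lower number from compound 1 to compound 3 (0.20 log units; within the scatter), which stayed within the scatter, so its loss is not expected to move the number much. Among the compounds with values here, the remaining change, a phenylethyl turned into a 2,3-dihydro-1H-inden-1-yl on the same amine nitrogen, has no direct precedent; the only other change at that nitrogen, a 10-fold higher number from compound 1 to compound 2 (1.00 log units; beyond the scatter), was a larger rearrangement and cost a modest amount. Within the data shown here, compound 4 keeps the secondary amine and the single aromatic ring of compound 1, so a step no larger than the scatter is expected, if anything a slightly higher number. The expected step is a 1.8-fold higher number from compound 3 to compound 4 (0.25 log units; within the scatter). For compound 4 the estimate is 16 nM, in the range 5 nM to 50 nM.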

Compound 4, half-maximal inhibitory concentration: 25 nM
Compound 4: the middle estimate sits 1.6-fold (0.19 log units) below what was measured; measured number inside the range.
By their numbers in this assay, from the lowest: compounds 3, 1 and 4 (each within the scatter of the next, the first and the last beyond it); then compound 2.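

In this assay, 2,3-dihydro-1H-inden-1-yl in place of 1-phenylethyl on the amine nitrogen gives a 1.8-fold higher number from compound 1 to compound 4 (0.25 log units; within the scatter) and so cannot be ordered against the open-chain group, which shows that this position accepts the closed ring. Replacing 1-(4-acetamidophenyl)ethyl at the same nitrogen gives a 2.8-fold higher number from compound 3 to compound 4 (0.45 log units; beyond the scatter) as a modest step, so the series now has a measured separation at this nitrogen even though compound 1 and compound 3 themselves cannot be ordered. The comparison with the other side chain gives a 5.6-fold lower number from compound 2 to compound 4 (0.75 log units; beyond the scatter) and shows that the high number of compound 2 does not extend to every replacement of the ((1-phenylethyl)amino)methyl group on the saturated ring carbon.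

Nothing available explains any of these steps. Still open, as far as these compounds go, are whether a methoxy group or a fluorine on the aromatic ring of the 2,3-dihydro-1H-inden-1-yl group would change the number, how a larger 1,2,3,4-tetrahydronaphthalen-1-yl ring would compare, and how the two separate mirror forms of compound 4 would compare with each other.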